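The source may report more compounds than this note shows. Statements on the series, on what has been measured and on what is new or still open speak of the compounds shown alone.

Working notes on the series, read in a functional assay on A549 cells (Homo sapiens) for cytotoxicity, read by MTT assay, with a stated time of 72 h; a lower number here means a stronger inhibitor, a higher number a weaker inhibitor. Compound 1 `CN(C)CCCCCn1c2c(c3ccccc31)C(=O)c1c[n+]([O-])c3ccccc3c1C2=O` gives 210 nM and compound 2 `O=C1c2c[n+]([O-])c3ccccc3c2C(=O)c2c1c1ccccc1n2CCCCn1ccnc1` gives 170 nM, with a 1.2-fold lower number from compound 1 to compound 2 (0.09 log units; within the scatter). Compound 3 `O=C1c2c[n+]([O-])c3ccccc3c2C(=O)c2c1c1ccccc1n2Cc1cn(CC(O)CO)nn1` has the highest number of the three at 880 nM. The steps that reach it are a 4.2-fold higher number from compound 1 to compound 3 (0.62 log units; beyond the scatter) and a 5.2-fold higher number from compound 2 to compound 3 (0.71 log units; beyond the scatter).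

Compound 4 `CN1CCN(CCCCn2c3c(c4ccccc42)C(=O)c2c[n+]([O-])c4ccccc4c2C3=O)CC1` is the next case, with 3-(4-methylpiperazin-1-yl)propyl in place of 1-(2,3-dihydroxypropyl)-1H-1,2,3-triazol-4-yl on a saturated chain carbon bound to an aromatic nitrogen. Here 3-(4-methylpiperazin-1-yl)propyl stands in place of 1-(2,3-dihydroxypropyl)-1H-1,2,3-triazol-4-yl on a saturated chain carbon bound to an aromatic nitrogen. This runs opposite to the two steps into compound 3, where that same triazolyl group replaced 4-(dimethylamino)butyl and 3-(1H-imidazol-1-yl)propyl. Going by the values given here, no measured compound carries the 4-methylpiperazin-1-yl group, so the reading rests on those two steps alone. A modest step to a lower number in this assay is therefore expected, back towards compound 1 and compound 2.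

The expected step is a 4.0-fold lower number from compound 3 to compound 4 (0.60 log units; beyond the scatter). The estimate for compound 4 is 220 nM, with an expected range of 90 nM to 520 nM.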

Compound 4, half-maximal inhibitory concentration: 90 nM
The estimate for compound 4 lay 2.4-fold (0.39 log units) above the measured number; low and high end bracket the measured number.
By their numbers in this assay, from the lowest: compounds 4, 2 and 1 (each within the scatter of the next, the first and the last beyond it); then compound 3.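

Going by these compounds alone, the swap of 1-(2,3-dihydroxypropyl)-1H-1,2,3-triazol-4-yl for 3-(4-methylpiperazin-1-yl)propyl on a saturated chain carbon bound to an aromatic nitrogen gives a 9.8-fold lower number from compound 3 to compound 4 (0.99 log units; beyond the scatter), so this position tolerates a ring-bearing chain at least as well as the earlier chains. 4-Methylpiperazin-1-yl is also the first group at the chain end to separate from the dimethylamino chain of compound 1, with a 2.3-fold lower number from compound 1 to compound 4 (0.37 log units; beyond the scatter), whereas it stays unresolved from 1H-imidazol-1-yl, with a 1.9-fold lower number from compound 2 to compound 4 (0.28 log units; within the scatter). No measurement on hand accounts for the size of these steps.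

The step from compound 3 to compound 4 changes chain and end group together, reading (1-(2,3-dihydroxypropyl)-1H-1,2,3-triazol-4-yl)methyl to 4-(4-methylpiperazin-1-yl)butyl, so the two contributions stay unseparated. Open too, as far as these compounds go, is how morpholin-4-yl or a carboxylic acid at the chain end, or the triazole on a butyl chain, would read.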